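The source may report more compounds than this note shows. Statements on the series, on what has been measured and on what is new or still open speak of the compounds shown alone.

Measured compounds:
compound 1 `CO[C@@H]1CC=C2NN(c3ccc(C)cc3)C(=O)C[C@]2(C)O1`, 25300 nM
compound 2 `CO[C@@H]1CC=C2NN(c3cc4ccccc4[nH]3)C(=O)C[C@]2(C)O1`, 19500 nM
compound 3 `CO[C@@H]1CC=C2NN(c3ccc(Cl)cc3)C(=O)C[C@]2(C)O1`, 31700 nM

In a functional assay on SK-N-SH cells (Homo sapiens) for inhibition, read by sulforhodamine B assay, with a stated time of 48 h (a lower number here means a stronger inhibitor, a higher number a weaker inhibitor), compound 2 gives the lowest of the three numbers, yet compound 1 and compound 3 sit within the scatter of it, so no ranking among them is secure. Compound 4 `CO[C@@H]1CC=C2NN(c3cc4ccccc4[nH]3)C(=O)C[C@]2(c2ccccc2)O1` differs from compound 2 by phenyl in place of methyl on a saturated ring carbon. Among the compounds with values here, the only measured step, a 1.3-fold higher number from compound 1 to compound 3 (0.10 log units; within the scatter), concerns the aromatic ring on the nitrogen, not the saturated ring carbon, so it says little about this change. Within the data shown here, no step touches that carbon. The expectation is therefore a step of a 1.0-fold higher number from compound 2 to compound 4 (0.01 log units; within the scatter), with no firm direction beyond the scatter. Compound 4 is estimated at 20000 nM, in a range from 6000 nM to 70000 nM.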

Compound 4, half-maximal inhibitory concentration: 9100 nM
Compound 4: the middle estimate sits 2.2-fold (0.34 log units) above what was measured; measured number inside the range.
By their numbers in this assay, from the lowest: compound 4; then compounds 2, 1 and 3 (each within the scatter of the next).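

In this assay, within the data shown here, putting phenyl in place of methyl on this saturated ring carbon, next to the ring oxygen, gives a 2.1-fold lower number from compound 2 to compound 4 (0.33 log units; beyond the scatter), the first step in this set that lies beyond the scatter, though it is modest. So this carbon can carry a much larger group without the number rising. Nothing available explains the drop. As far as these compounds go, whether an aromatic ring is needed here stays open, as a cyclohexyl group, an ethyl group or a longer chain bearing an amine would show. From the compounds shown here alone, whether the same change works with the other groups on the nitrogen also stays open.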